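Amide chain variation in the channel binding series

The source may report more compounds than this note shows. Statements on the series, on what has been measured and on what is new or still open speak of the compounds shown alone.

Measured compounds in an assay on LtK cells with ATP-sensitive inward rectifier potassium channel 11 (Homo sapiens) as the target; on this read-out lower numbers stand for an effect already at smaller amounts and higher numbers for an effect only at larger amounts of compound:
- compound 1, `CCC(CC)C(=O)Nc1c(C(O)(C(F)(F)F)C(F)(F)F)ccc2ccccc12`: 4340 nM
- compound 2, `COCC(=O)Nc1c(C(O)(C(F)(F)F)C(F)(F)F)ccc2ccccc12`: 213 nM

Among the compounds with values here, compound 2 stands at the lowest of the two numbers, with compound 1 at the higher one; the step of a 20-fold lower number from compound 1 to compound 2 (1.31 log units; beyond the scatter) is the only measured step. Compound 3, `O=C(CCc1ccccc1)Nc1c(C(O)(C(F)(F)F)C(F)(F)F)ccc2ccccc12`, is not yet measured. It differs from compound 2 by benzyl in place of methoxy on a saturated chain carbon bound to a carbonyl carbon; cut one bond further out, the difference reads methoxymethyl to phenethyl. Within the data shown here, only the step from compound 1 to compound 2 bears on it, and that step was large: replacing pentan-3-yl with methoxymethyl on the carbonyl carbon brought the number down sharply. Compound 3 moves away from methoxymethyl again, toward a chain more like that of compound 1, so a rise in the number is expected, of the size a 7.0-fold higher number from compound 2 to compound 3 (0.85 log units; beyond the scatter), because a 20-fold lower number from compound 1 to compound 2 (1.31 log units; beyond the scatter) ran the other way. Compound 3 is estimated at 1500 nM, within 400 nM to 6000 nM.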

Compound 3, half-maximal effective concentration: 1750 nM
Estimate against measurement, compound 3: 1.2-fold (0.07 log units) below; measured number inside the range.
By their numbers in this assay, from the lowest: compound 2; then compound 3; then compound 1.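

In this assay, the step of an 8.2-fold higher number from compound 2 to compound 3 (0.91 log units; beyond the scatter) shows that phenethyl, with its six-membered aromatic ring and no hydrogen-bond acceptor, does not match methoxymethyl on this carbonyl carbon. The step of a 2.5-fold lower number from compound 1 to compound 3 (0.39 log units; beyond the scatter) shows that two chains without the methoxy oxygen also differ from each other beyond the scatter, so the presence or absence of that oxygen does not alone set the number at this position. No measurement at hand accounts for either step.

Still open, from the compounds shown here alone, is how much of the low number of compound 2 depends on the oxygen itself, a question that a propyl chain on the same carbonyl carbon would address directly. Also open, going by these compounds, is how this position responds to an aminomethyl group or to a longer ether chain such as ethoxymethyl.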